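The compounds below may be only part of what the source reports. "The series", "measured", "known", "first", "only" and "open" are said of these compounds alone.

Measured so far in an assay on isolated protein for inhibition of Gonadotropin-releasing hormone receptor (Homo sapiens); a higher number here means a weaker inhibitor, a lower number a stronger inhibitor:
compound 1, `COc1ccc([N+](=O)[O-])cc1CSc1nc2cc(NC(=O)NC(C)(C)C)ccc2n1Cc1ccccc1`, 28 nM
compound 2, `COc1ccc([N+](=O)[O-])cc1CSc1nc2cc(NC(=O)NC(C)(C)C)ccc2n1Cc1cccnc1`, 33 nM

Both share the same core and differ only at the group on the saturated chain carbon bound to the aromatic nitrogen; the step is a 1.2-fold higher number from compound 1 to compound 2 (0.07 log units; within the scatter). Compound 2 therefore carries the higher of the two numbers in this assay, but its gap to compound 1 lies within the scatter, so the two are not separated.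

Compound 3, `COc1ccc([N+](=O)[O-])cc1CSc1nc2cc(NC(=O)NC(C)(C)C)ccc2n1-c1ccccc1`, is still to be measured in this assay. Against compound 2 the change is phenyl in place of (pyridin-3-yl)methyl on an aromatic nitrogen. Going by the values given here, the only measured step, the one between compound 1 and compound 2, swapped one six-membered aromatic ring for another while keeping the saturated chain carbon; no measured pair removes that carbon or places an aromatic ring directly on the aromatic nitrogen. That step bears on the present one only in showing that the ring identity itself mattered little. On these data alone, the shortening of the link is untested, so a wide range is taken.

For compound 3 a step of a 1.8-fold higher number from compound 2 to compound 3 (0.26 log units; within the scatter) is expected in this assay, with the number estimated at 60 nM and a range of 15 nM to 300 nM.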

Compound 3, half-maximal inhibitory concentration: 350 nM
For compound 3 the middle estimate is 5.8-fold (0.77 log units) below the measured one, outside the stated range (above it).
By their numbers in this assay, from the lowest: compounds 1 and 2 (each within the scatter of the next); then compound 3.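

Notes on the group on the aromatic nitrogen, in this assay: the link to the ring matters here in a way the ring identity did not, since the swap of phenyl for pyridin-3-yl on the saturated chain carbon stayed within the scatter (a 1.2-fold higher number from compound 1 to compound 2 (0.07 log units; within the scatter)), whereas the two changes that remove that carbon are large. Phenyl in place of benzyl gives (a 13-fold higher number from compound 1 to compound 3 (1.10 log units; beyond the scatter)), and phenyl in place of (pyridin-3-yl)methyl gives (an 11-fold higher number from compound 2 to compound 3 (1.03 log units; beyond the scatter)), so among these three compounds compound 3 stands apart from the unseparated pair of compound 1 and compound 2, and the two steps agree with each other whichever ring leaves. No measured evidence on the origin of this step is at hand.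

Still open, on these data alone, is whether the effect follows the length of the link, as a longer chain such as 2-phenylethyl on the same nitrogen would show, or whether a ring is needed there at all, as a plain methyl or cyclohexylmethyl group would show. Also open, as far as these compounds go, is whether a pyridin-3-yl ring set directly on the aromatic nitrogen would track phenyl.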